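A few compounds are considered here, and "the series" means these few. Any claim that something is new, unique, unknown or untested is made for them only; others in the source may bear on it.

Measured so far in a functional assay on MCF7 cells (Homo sapiens) for cytotoxicity, read by CellTiter-Glo, with a stated time of 5 days; a higher number here means a weaker inhibitor, a lower number a stronger inhibitor:
compound 1, `CC/C(=C(/c1ccc(/C=C/C(=O)O)cc1)c1ccc2[nH]ncc2c1)c1ccccc1`, 7.2 nM
compound 2, `CC/C(=C(/c1ccc(/C=C/C(=O)O)cc1)c1cc2cn[nH]c2cc1C)c1ccccc1`, 468 nM
compound 3, `CC/C(=C(/c1ccc(/C=C/C(=O)O)cc1)c1ccc2[nH]nc(F)c2c1)c1ccccc1`, 5 nM

Compound 3 holds the lowest number of the three. Its nearest neighbour is compound 1, at a 1.4-fold lower number from compound 1 to compound 3 (0.16 log units; within the scatter), a gap within the scatter, so no order between compound 1 and compound 3 can be read. The furthest is compound 2, at a 94-fold lower number from compound 2 to compound 3 (1.97 log units; beyond the scatter), a large gap.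

Compound 4, `CC/C(=C(/c1ccc(/C=C/C(=O)O)cc1)c1cc2cn[nH]c2cc1F)c1ccccc1`, has not been measured in this assay. It differs from compound 3 by 6-fluoro-1H-indazol-5-yl in place of 3-fluoro-1H-indazol-5-yl on a double-bonded chain carbon bound to an aromatic carbon and a double-bonded chain carbon. For the measured compounds named here, two measured steps bear on this. The step of a 65-fold higher number from compound 1 to compound 2 (1.81 log units; beyond the scatter) put a methyl on the aromatic carbon of the indazole ring that carries the fluoro in the 6-fluoro-1H-indazol-5-yl group of compound 4, and the number rose sharply. The step of a 1.4-fold lower number from compound 1 to compound 3 (0.16 log units; within the scatter) shows that fluoro within 3-fluoro-1H-indazol-5-yl changes nothing beyond the scatter. Compound 4 therefore moves the fluoro to the carbon where methyl was harmful in compound 2, and a rise beyond the scatter is expected, though fluoro is not methyl and the size is uncertain; the expected step is a 12-fold higher number from compound 3 to compound 4 (1.08 log units; beyond the scatter). Compound 4 is estimated at 60 nM, with a range from 15 nM to 300 nM.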

Compound 4, half-maximal inhibitory concentration: 47 nM
Beside the measured number, compound 4's estimate is 1.3-fold (0.11 log units) above it; low and high end bracket the measured number.
By their numbers in this assay, from the lowest: compounds 3 and 1 (each within the scatter of the next); then compound 4; then compound 2.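

Moving the fluoro from the 3-fluoro-1H-indazol-5-yl group to the 6-fluoro-1H-indazol-5-yl group changes the outcome in this assay (a 9.4-fold higher number from compound 3 to compound 4 (0.97 log units; beyond the scatter)), so the same atoms on the same chain carbon do not give the same result, and the placement of the fluoro within the group matters. The rise seen with methyl is therefore not confined to methyl, since fluoro on that ring carbon also lifts the number beyond the scatter relative to the unsubstituted group (a 6.5-fold higher number from compound 1 to compound 4 (0.81 log units; beyond the scatter)), yet fluoro recovers a substantial part of what methyl lost (a 10-fold lower number from compound 2 to compound 4 (1.00 log units; beyond the scatter)), which makes this carbon sensitive to the identity of its substituent and not only to whether one is present. Nothing available gives a measured reason for this ordering of hydrogen, fluoro and methyl on that carbon.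

From the compounds shown here alone, with only these three substituents on that ring carbon, it stays open whether the number climbs steadily from one group to the next or follows some other trend. Chloro, methoxy, hydroxyl or an amine on the same carbon would test this, and a compound carrying fluoro at both sites would show whether the two changes add.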